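The source may report more compounds than this note shows. Statements on the series, on what has been measured and on what is new or still open speak of the compounds shown alone.

Compound 1 `CC(C)COc1ncc(-c2cn(C)c3cc(C(=O)NS(C)(=O)=O)ccc23)cc1Cl` gives 216 nm/s in an ADME assay for permeability, using PAMPA, at pH 7.4; a higher number here means that the compound crosses the layer faster, a lower number that the compound crosses the layer more slowly.
Compound 2 `CC(C)COc1ncc(-c2cn(C)c3cc(C(=O)NS(C)(=O)=O)c(F)cc23)cc1Cl` gives 205 nm/s in this assay.
Compound 3 `Cn1cc(-c2ccc(C(F)(F)F)cc2)c2cc(F)c(C(=O)NS(C)(=O)=O)cc21` gives 140 nm/s in this assay.

Compound 4 `Cn1cc(-c2ccc(C(F)(F)F)cc2)c2ccc(C(=O)NS(C)(=O)=O)cc21` has not yet been measured in this assay. It is made from compound 3 by one change, (hydrogen in place of fluoro on an aromatic carbon). The same change has already been made once among the measured compounds, from compound 2 to compound 1, where it is hydrogen in place of fluoro on an aromatic carbon; there it gave a 1.1-fold higher number from compound 2 to compound 1 (0.02 log units; within the scatter). The two places are described in the same words, so this is the same change made on a different core. How the core of compound 3 differs from the core of compound 2 is not broken down here; the two values show that compound 3 sits within the scatter of both compound 2 and compound 1.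

With one measured example of this change showing essentially no movement, the step from compound 3 to compound 4 in this assay is expected to be about a 1.1-fold higher number from compound 3 to compound 4 (0.04 log units; within the scatter), resting on a 1.1-fold higher number from compound 2 to compound 1 (0.02 log units; within the scatter). Compound 4 is therefore estimated at 155 nm/s, most likely between 90 nm/s and 260 nm/s.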

Compound 4, apparent permeability: 171 nm/s
The estimate for compound 4 lay 1.1-fold (0.04 log units) below the measured number, within the range that was stated.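

In this assay, putting hydrogen in place of fluoro on an aromatic carbon gave a 1.2-fold higher number from compound 3 to compound 4 (0.09 log units; within the scatter), so this second example, like the first, lies within the usual scatter of the measurement. Set side by side, the two examples do not differ, and so far the change carries from one core to the other without a visible difference: the same change on two cores in this assay, a 1.1-fold higher number (0.02 log units; within the scatter) from compound 2 to compound 1 and a 1.2-fold higher number (0.09 log units; within the scatter) from compound 3 to compound 4, 1.2-fold (0.06 log units) apart, within the scatter of two such steps. Among these compounds, this rests on only two pairs of compounds, however, and steps this small cannot separate a slight real effect from no effect, nor do they show what the change would do on any other core.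

The compounds shown carry only hydrogen or fluoro at this place, which leaves open what a chlorine atom, a methoxy group or an amine would do there. Going by these compounds, it also remains open whether the swap would behave the same way if a carboxylic acid stood in place of the (methylsulfonyl)carbamoyl group.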